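The source may hold more compounds than are shown below. What is called first, only, known or untested is meant among the compounds shown, and "the series" means these compounds.

Compounds measured so far:
compound 1 `CC1=C(C(=O)CC(C)C)C(c2ccco2)NC(=O)N1` with 31%;
compound 2 `CCN(CC)C(=O)C1=C(C)NC(=O)NC1c1ccco1` with 19%;
compound 3 `CCC(CC)OC(=O)C1=C(C)NC(=O)NC1c1ccco1` with 1%.

In an assay on membranes from HeLa cells for displacement of a labelled ligand from adenosine receptor A3 (Homo sapiens), read by scintillation counting, with a stated time of 180 min, tested at 1 uM (on this read-out lower numbers stand for less inhibition and higher numbers for more inhibition at the one concentration tested (going by the name of the read-out)), compound 3 gives the lowest of the three numbers. The step of a number 30 percentage points lower from compound 1 to compound 3 (beyond the scatter) and the step of a number 18 percentage points lower from compound 2 to compound 3 (beyond the scatter) both lead to compound 3, and both are modest but beyond the scatter, so the number for compound 3 lies below those of compound 1 and compound 2 on this read-out. Compound 1 and compound 2 are separated by a number 12 percentage points lower from compound 1 to compound 2 (beyond the scatter).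

Compound 4 `CC1=C(C(=O)OC2CCCCC2)C(c2ccco2)NC(=O)N1` is the next compound to be measured. It differs from compound 3 in one place: cyclohexyl in place of pentan-3-yl on an oxygen next to a carbonyl group. Among the compounds with values here, none of the measured steps touches the group on the ester oxygen; the three steps concern the substituent on the carbonyl carbon, and they show only that the ester in compound 3 sits lowest. For this reason the expected step in this assay from compound 3 to compound 4 is small and of uncertain direction, most likely none beyond the scatter, estimated as a number 5 percentage points higher from compound 3 to compound 4 (within the scatter). Compound 4 is therefore expected to give about 6% in this assay, with a range from 0% to 25%.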

Compound 4, a percentage reported as inhibition, at one concentration (the size of the read-out at that concentration, not a potency): 4%
Beside the measured number, compound 4's estimate is 2 percentage points above it, within the range that was stated.
By their numbers in this assay, from the lowest: compounds 3 and 4 (each within the scatter of the next); then compound 2; then compound 1.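

In this assay, cyclohexyl in place of pentan-3-yl on an oxygen next to a carbonyl group, the only change at this position among the compounds shown, gives a number 3 percentage points higher from compound 3 to compound 4 (within the scatter) and so does not separate the six-membered ring of carbon only from the ring-free group it replaces. The low standing of compound 3 therefore recurs with a second group on the ester oxygen, as the steps of a number 15 percentage points lower from compound 2 to compound 4 (beyond the scatter) and a number 27 percentage points lower from compound 1 to compound 4 (beyond the scatter) both stay beyond the scatter, in the same direction as the steps that lead to compound 3. Nothing at hand bears on why the numbers fall this way.

Going by these compounds, both groups on this oxygen consist of carbon and hydrogen alone, so it remains open whether a short chain such as ethyl, an aromatic ring such as phenyl, or a chain carrying an amine or a carboxylic acid would give a different number. Also open is whether a longer chain or a benzyl group on the carbonyl carbon would raise the number beyond that of the isobutyl ketone, and how any of these compounds would rank over a range of concentrations.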